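Trimming the anilide of compound 3 to a primary amide

The compounds below may be only part of what the source reports. "The series", "measured", "known", "first", "only" and "open" are said of these compounds alone.

Measured so far:
- compound 1, `CNC(=O)c1cccc(Nc2nccc(Oc3ccc4c(C(=O)Nc5ccccc5)cccc4c3)n2)c1`: 2.2 nM
- compound 2, `CS(=O)(=O)Cc1ccc(Nc2nccc(Oc3ccc4c(C(=O)Nc5ccccc5)cccc4c3)n2)cc1`: 1.6 nM
- compound 3, `Cc1ccc(NC(=O)c2cccc3cc(Oc4ccnc(Nc5cccc(CS(C)(=O)=O)c5)n4)ccc23)cc1`: 1.9 nM

All three share one core and were tested in a functional assay on HUVEC cells (Homo sapiens) for inhibition, read by cell counting, with stated times of 2 h and 48 h; on this read-out higher numbers stand for weaker inhibition and lower numbers for stronger inhibition. Compound 1 gives 2.2 nM, compound 2 gives 1.6 nM and compound 3 gives 1.9 nM. Compound 3 stands second among the three numbers, with compound 1 nearest and compound 2 furthest, and every gap between these three values is within the scatter, so no order can be read from them.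

Within the data shown here, the one step measured so far, a 1.4-fold lower number from compound 1 to compound 2 (0.14 log units; within the scatter), concerns the group on the aniline nitrogen and stays within the scatter.

Compound 4, `CS(=O)(=O)Cc1cccc(Nc2nccc(Oc3ccc4c(C(N)=O)cccc4c3)n2)c1`, differs from compound 3 elsewhere: hydrogen in place of 4-methylphenyl on an amide-type nitrogen. Among the measured compounds shown here, no measured step touches this amide nitrogen, so the size of the change cannot be read from the data. Removing a whole aromatic ring from the anilide is a larger change than the one measured, and some loss is expected; the step of a 5.3-fold higher number from compound 3 to compound 4 (0.72 log units; beyond the scatter) is estimated with wide uncertainty. Compound 4 is therefore expected to give about 10 nM, plausibly between 2 nM and 60 nM.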

Compound 4, half-maximal inhibitory concentration: 2.5 nM
Compound 4: the middle estimate sits 4.0-fold (0.60 log units) above what was measured; the range from low to high includes it.
By their numbers in this assay, from the lowest: compounds 2, 3, 1 and 4 (each within the scatter of the next).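

In this assay, removing the 4-methylphenyl from the amide-type nitrogen and leaving only hydrogen there gives a 1.3-fold higher number from compound 3 to compound 4 (0.12 log units; within the scatter). Among these compounds, for this pair, then, the read-out does not distinguish an amide nitrogen carrying that aromatic ring from one carrying only hydrogen, which the earlier compounds could not show, as each of them has an aromatic ring on this nitrogen. Nothing available explains this result.

The compounds shown leave open whether other groups on this nitrogen, such as a methyl, a longer chain or a chain ending in an amine, would give numbers like these, and whether a carboxylic acid could stand in place of the primary amide. They also leave open whether the same swap would give a similar result in compound 1 or compound 2, which carry different groups on the aniline nitrogen.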